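The source may hold more compounds than are shown below. What is called first, only, known or untested is meant among the compounds shown, and "the series" means these compounds.

Compound 1, `CCCCc1nc(=O)c(S(=O)(=O)c2ccc(-c3ccc(F)nc3)cc2)c(O)n1-c1c(OC)cccc1OC`, gives 2% in an ADME assay on microsomes from liver (Rattus norvegicus) for metabolic stability, using NADPH, with a stated time of 10 min; on this read-out higher numbers stand for a more stable compound and lower numbers for a less stable compound.
Compound 2, `COc1cccc(OC)c1-n1c(COC(C)C)nc(=O)c(S(=O)(=O)c2ccc(-c3ccc(F)nc3)cc2)c1O`, gives 30%.

Compound 1 stands lowest of the two measured numbers. Within the data shown here, its nearest neighbour is compound 2, and the only measured step, a number 28 percentage points higher from compound 1 to compound 2 (beyond the scatter), comes from isopropoxy in place of propyl on a saturated chain carbon bound to an aromatic carbon. Compound 3, `CCCCc1nc(=O)c(S(=O)(=O)c2ccc(C3CC3)cc2)c(O)n1-c1c(OC)cccc1OC`, has not yet been measured. It differs from compound 1 at another place: cyclopropyl in place of 6-fluoropyridin-3-yl on an aromatic carbon.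

Among the measured compounds shown here, no measured step touches the aromatic carbon where this change sits, so the step from compound 1 to compound 2 offers no direct guide for the new change; it shows only that a single substitution elsewhere moved the read-out beyond the scatter. With compound 1 already near the floor of the read-out, the number for compound 3 is expected to stay close to it, with the change a number 3 percentage points higher from compound 1 to compound 3 (within the scatter) estimated to lie within the scatter. Compound 3 is therefore estimated at 5%, between 0% and 20%.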

Compound 3, percent of the compound remaining: 59%
Estimate against measurement, compound 3: 54 percentage points below; measured number above the stated range.
By their numbers in this assay, from the lowest: compound 1; then compound 2; then compound 3.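

Read in this assay, the step of a number 57 percentage points higher from compound 1 to compound 3 (beyond the scatter) is large and shows that the aromatic carbon para to a large group, which no earlier step touched, strongly affects this read-out. Here, 6-fluoropyridin-3-yl, with its six-membered aromatic ring, 7 heavy atoms and 1 hydrogen-bond acceptor, gives way to cyclopropyl, with its three-membered non-aromatic ring, 3 heavy atoms and 0 hydrogen-bond acceptors, so several features change in a single step. No measurement shown here identifies which of these differences accounts for the higher number, and nothing shown explains the result.

A simple phenyl ring, a methyl group or a longer chain on the same carbon could help show whether the result depends on cyclopropyl itself or mainly on the absence of 6-fluoropyridin-3-yl. The compounds shown also leave open whether cyclopropyl and the isopropoxy group of compound 2, each tied to a step beyond the scatter in its own comparison with compound 1, would add up when placed together on the same core.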